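A Second Chloro Group Added to Compound 3

The source may hold more compounds than are shown below. What is called first, only, known or untested is meant among the compounds shown, and "the series" means these compounds.

Measured compounds:
compound 1 `Cc1ccc(C2=NN(c3ccc(S(C)(=O)=O)cc3)C(=O)CC2)cc1` – 60.5%
compound 2 `Cc1cc(O)ccc1C1=NN(c2ccc(S(C)(=O)=O)cc2)C(=O)CC1` – 52.6%
compound 3 `CS(=O)(=O)c1ccc(N2N=C(c3ccc(Cl)cc3)CCC2=O)cc1` – 36.8%

In a functional assay on the whole organism (strain Wistar) for inhibition, with Rattus norvegicus as the target, read by paw edema, with stated times of 30 min and 5 h, at a dose of 0.05 mmol/kg by the oral route (a lower number here means less inhibition, a higher number more inhibition at the dose given (going by the name of the read-out)), compound 3 stands lowest of the three numbers, beyond the scatter from both compound 1 and compound 2. Compound 4 `CS(=O)(=O)c1ccc(N2N=C(c3ccc(Cl)c(Cl)c3)CCC2=O)cc1` differs from it by chloro in place of hydrogen on an aromatic carbon. Among the measured compounds shown here, two measured steps bear on this: the chloro-bearing compound 3 sits below compound 1 by a number 23.7 percentage points lower from compound 1 to compound 3 (beyond the scatter) and below compound 2 by a number 15.8 percentage points lower from compound 2 to compound 3 (beyond the scatter). For the measured compounds named here, no measured step adds a second chloro group, so the expectation is a small change at most, likely downward or none beyond the scatter. Compound 4 is therefore expected to give 32%, in the range 15% to 50%, an estimated step of a number 4.8 percentage points lower from compound 3 to compound 4 (within the scatter).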

Compound 4, a percentage reported as inhibition, in the whole organism at one dose (the size of the read-out at that dose, not a potency): 34.2%
Beside the measured number, compound 4's estimate is 2.2 percentage points below it; measured number inside the range.
By their numbers in this assay, from the lowest: compounds 4 and 3 (each within the scatter of the next); then compounds 2 and 1 (each within the scatter of the next).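

Adding chloro ortho to a chloro group gives a number 2.6 percentage points lower from compound 3 to compound 4 (within the scatter) in this assay and so, at this single dose, this place takes a second chlorine with no change that stands out from the scatter. The 3,4-dichlorophenyl group still reads low against the other two groups, with a number 18.4 percentage points lower from compound 2 to compound 4 (beyond the scatter) and a number 26.3 percentage points lower from compound 1 to compound 4 (beyond the scatter) as the steps. Nothing measured here gives a reason for this result.

On these data alone, what an amine or a carboxylic acid at this same place would give remains open, as does the effect of a methoxy group.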